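This account rests on a few compounds, and the source may have more. Where it says the series, first, only, none or still open, it means among the compounds named here.

Measured in a functional assay on Raji cells (Homo sapiens) for cytotoxicity, with a stated time of 72 h; a higher number here means that more compound is needed for the effect, a lower number that less compound is needed:
- Compound 1 `C=C[C@@](C)(/C=C/c1ccc(OS(=O)(=O)c2ccc(C)cc2)cc1)CCC=C(C)C`: > 26000 nM, a limit and not a number
- Compound 2 `C=C[C@@](C)(/C=C/c1ccc(O)cc1)CC/C=C(C)/C=C/C(=O)OCC`: > 26000 nM, a limit and not a number
- Compound 3 `COc1ccc(/C=C/[C@@](C)(/C=C/c2ccc(O)c(C=O)c2)CCC=C(C)C)cc1`: 13000 nM

Compound 3 is the only one of the three with an actual number, 13000 nM. The other two results are a limit: the limit of > 26000 nM in this assay, at which 2 of the 3 values shown sit.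

Compound 4 `COc1ccc(/C=C/[C@@](C)(/C=C/c2ccc(O)cc2)CCC=C(C)C)cc1` has hydrogen in place of formyl on an aromatic carbon, ortho to a hydroxy group, so 3-formyl-4-hydroxyphenyl becomes 4-hydroxyphenyl: hydrogen in place of formyl on an aromatic carbon. Among the compounds with values here, no measured pair isolates this change, so its size in this assay can only be expected. Compound 1 and compound 2 also lack the formyl and gave only a limit, though they differ from compound 3 elsewhere too. A modest move towards a higher number is therefore expected, and the assay may report only a limit. The expected change is a 1.8-fold higher number from compound 3 to compound 4 (0.27 log units; within the scatter). For compound 4 the estimated value is 24000 nM. The expected range for compound 4 runs from 11000 nM to 50000 nM.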

Compound 4, half-maximal effective concentration: > 26000 nM
Compound 4: only a limit was reported; the forecaster's own chance of this, stated with the estimate: 55%; at least 1.0-fold (0.03 log units) between middle value and limit.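

Within the data shown here, replacing formyl with hydrogen, with the rest of the molecule unchanged, gives the one direct comparison at this position in this assay, and it amounts to an at least 2.0-fold higher number from compound 3 to compound 4 (0.30 log units; that floor lies within the scatter). Compound 4 gives > 26000 nM, which is a limit and not a number. In this pair, then, losing the formyl group turns a measured number into a limit, but the true size of the step stays unknown, since only its floor can be read: the limit of > 26000 nM in this assay, at which 3 of the 4 values shown sit.

The compounds shown leave open whether another group on this aromatic carbon, such as an amine, a carboxylic acid or a longer chain, would give a measured number. They also leave open whether the formyl group would give the same result without the hydroxy group it sits ortho to.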